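This account rests on a few compounds, and the source may have more. Where it says the series, first, only, none or still open, it means among the compounds named here.

Compound 1 `CC(=O)CCSC(=S)NCc1cccnc1`: 4220 nM
Compound 2 `O=C(O)CCSC(=S)NCc1cccnc1`: 9320 nM

Among the measured compounds shown here, in a functional assay on MDA-MB-468 cells (Homo sapiens) for cytotoxicity, read by resazurin assay, with a stated time of 72 h (on this read-out higher numbers stand for weaker inhibition and lower numbers for stronger inhibition), compound 2 stands as the higher of the two numbers, the weaker inhibitor of the pair; its only neighbour lies one step away, a 2.2-fold higher number from compound 1 to compound 2 (0.34 log units; beyond the scatter), a change of hydroxy in place of methyl on a carbonyl carbon. Compound 3 `CCCCOC(=O)CCSC(=S)NCc1cccnc1` differs from compound 2 by butyl in place of hydrogen on an oxygen next to a carbonyl group. For the measured compounds named here, the one measured step that bears on this is that modest one, and the hydroxy that entered in it is now capped by butyl. A modest step downward is therefore expected, a 2.1-fold lower number from compound 2 to compound 3 (0.32 log units; beyond the scatter). Compound 3 is estimated at 4500 nM, with a range from 1500 nM to 13000 nM.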

Compound 3, half-maximal inhibitory concentration: 12800 nM
Compound 3: middle estimate off by 2.8-fold (0.45 log units), on the low side; the measured number falls inside the stated range.
By their numbers in this assay, from the lowest: compound 1; then compounds 2 and 3 (each within the scatter of the next).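

Replacing hydroxy with butoxy on this carbonyl carbon gives a 1.4-fold higher number from compound 2 to compound 3 (0.14 log units; within the scatter) in this assay, so this added butyl leaves the number unchanged within the scatter. Butoxy in place of methyl gives a 3.0-fold higher number from compound 1 to compound 3 (0.48 log units; beyond the scatter) and, like hydroxy, leaves compound 1 with the lowest number of the three. Nothing shown explains why methyl stands apart from the other two groups.

On these data alone, whether a shorter chain such as methyl on the same oxygen, or a longer chain, would behave like butyl remains open. So does the effect of an amine on this carbonyl carbon.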